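Urea aryl swap: dichloro for difluoro in the series

The source may report more compounds than this note shows. Statements on the series, on what has been measured and on what is new or still open speak of the compounds shown alone.

Three analogues share one core and differ only in the aryl group on the urea nitrogen. Compound 1 `CN(C)CCCn1cnnc1-c1cc(Oc2ccc(NC(=O)Nc3cccc(C(F)(F)F)c3)cc2F)ccn1` gives 13300 nM in a functional assay on MDA-MB-231 cells (Homo sapiens) for antiproliferative activity, read by MTT assay, with a stated time of 72 h; a higher number here means a weaker inhibitor, a lower number a stronger inhibitor. Compound 2 `CN(C)CCCn1cnnc1-c1cc(Oc2ccc(NC(=O)Nc3ccccc3C(F)(F)F)cc2F)ccn1` gives 40500 nM in this assay, and compound 3 `CN(C)CCCn1cnnc1-c1cc(Oc2ccc(NC(=O)Nc3ccc(F)c(F)c3)cc2F)ccn1` gives 25300 nM. Compound 3 stands second highest of the three numbers; the step of a 1.6-fold lower number from compound 2 to compound 3 (0.20 log units; within the scatter) and the step of a 1.9-fold higher number from compound 1 to compound 3 (0.28 log units; within the scatter) are both within the scatter, so no order among these three can be claimed.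

Compound 4 `CN(C)CCCn1cnnc1-c1cc(Oc2ccc(NC(=O)Nc3ccc(Cl)cc3Cl)cc2F)ccn1` is not yet measured. The change is 2,4-dichlorophenyl in place of 3,4-difluorophenyl on an amide-type nitrogen. Among the compounds with values here, two measured steps bear on it. Within the data shown here, the only step beyond the scatter is a 3.0-fold higher number from compound 1 to compound 2 (0.48 log units; beyond the scatter), where the trifluoromethyl moves to the 2-position of the phenyl. Compound 4 carries a chlorine in the 2-position of its phenyl, so a higher number is the more likely outcome, though the 3,4-difluoro to 2-trifluoromethyl comparison, a 1.6-fold lower number from compound 2 to compound 3 (0.20 log units; within the scatter), is itself within the scatter, so the evidence is thin.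

Expected for compound 4 is therefore a modest rise, a 1.6-fold higher number from compound 3 to compound 4 (0.20 log units; within the scatter), giving an estimated 40000 nM, with a range of 14000 nM to 110000 nM.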

Compound 4, half-maximal inhibitory concentration: 7490 nM
Estimate against measurement, compound 4: 5.3-fold (0.73 log units) above; the whole stated range lies above it.
By their numbers in this assay, from the lowest: compounds 4, 1, 3 and 2 (each within the scatter of the next, the first and the last beyond it).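

In this assay the change to 2,4-dichlorophenyl on the amide-type nitrogen gives a 3.4-fold lower number from compound 3 to compound 4 (0.53 log units; beyond the scatter) as the first step away from 3,4-difluorophenyl that clears the scatter, whereas compound 3 could not be separated from compound 1 or compound 2. The step of a 5.4-fold lower number from compound 2 to compound 4 (0.73 log units; beyond the scatter) is also beyond the scatter, so the two aryl groups named with a 2-substituent do not behave alike: compound 2 fits the idea that such a group goes with a higher number, and compound 4 goes against it. Against 3-(trifluoromethyl)phenyl, a 1.8-fold lower number from compound 1 to compound 4 (0.25 log units; within the scatter) stays within the scatter, so compound 1 and compound 4 cannot be ordered and the aryl groups of these two remain equivalent on this read-out.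

No measurement here accounts for the size or direction of these steps. Compound 4 alters the halogen and its placement on the phenyl together, leaving the two unseparated, and a 2,4-difluorophenyl or a 3,4-dichlorophenyl on the same nitrogen would pull them apart.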